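The source may report more compounds than this note shows. Statements on the series, on what has been measured and on what is new or still open speak of the compounds shown alone.

Measured so far in an assay on HEK293 cells for displacement of a labelled ligand from metabotropic glutamate receptor 5 (Rattus norvegicus); on this read-out higher numbers stand for weaker inhibition and lower numbers for stronger inhibition:
compound 1 `O=C(Nc1cc(-c2ccccc2)nn1-c1ccccc1)c1ccccc1` gives 4180 nM
compound 2 `O=C(Nc1cc(-c2ccccc2)nn1-c1ccccc1)c1cccc([N+](=O)[O-])c1` gives 2220 nM
compound 3 `O=C(Nc1cc(-c2ccccc2)nn1-c1ccccc1)c1ccc(C(F)(F)F)cc1` gives 990 nM

Compound 1 has the highest number of the three; the gap to compound 2 lies within the scatter, the gap to compound 3 beyond it. Compound 4 `COc1cccc(-c2cc(NC(=O)c3ccccc3)n(-c3ccccc3)n2)c1` differs from compound 1 by methoxy in place of hydrogen on an aromatic carbon. Neither measured step touches that ring: a 1.9-fold lower number from compound 1 to compound 2 (0.27 log units; within the scatter) and a 4.2-fold lower number from compound 1 to compound 3 (0.63 log units; beyond the scatter) both alter the ring on the carbonyl. Within the data shown here, they show only that adding a group to an aromatic ring of this core gave at most a modest lowering. Among the measured compounds shown here, with no step on the ring in question, the expected change is small, a 1.2-fold lower number from compound 1 to compound 4 (0.08 log units; within the scatter). Compound 4 is therefore estimated at 3500 nM, between 1200 nM and 10000 nM.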

Compound 4, inhibition constant: 3200 nM
For compound 4 the middle estimate is 1.1-fold (0.04 log units) above the measured one, and the stated range covers the measured number.
By their numbers in this assay, from the lowest: compound 3; then compounds 2, 4 and 1 (each within the scatter of the next).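

In this assay the change from phenyl to 3-methoxyphenyl gives a 1.3-fold lower number from compound 1 to compound 4 (0.12 log units; within the scatter) and is the first change shown on a ring other than the one on the carbonyl. At this place, meta to a large group, methoxy leaves the number within the scatter of compound 1. No measurement shown here speaks to why. The compounds shown leave open whether an amine, a carboxylic acid or a longer chain such as butoxy at this same place would shift the number beyond the scatter.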